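The source may report more compounds than this note shows. Statements on the series, on what has been measured and on what is new or still open speak of the compounds shown alone.

Compound 2 `Cc1ccc(C(=O)c2ccn(-c3ccc4c(c3)B(O)OC4)c2)cc1` is one of three measured analogues in the series. In an ADME assay on L929 cells (Mus musculus) for cytotoxicity, read by resazurin assay, with a stated time of 72 h (a higher number here means a weaker inhibitor, a lower number a stronger inhibitor), compound 2 gives > 10 ug/mL, which is a limit of the assay and not a number. Compound 1 `OB1OCc2ccc(-n3cc(Sc4ccc(Cl)cc4)c4ccccc43)cc21` in this assay gives > 10 ug/mL, also a limit. Compound 3 `CC(=O)OCc1ccc(C(=O)c2ccn(-c3ccc4c(c3)B(O)OC4)c2)cc1` in this assay gives 10 ug/mL. Among the measured compounds shown here, the only measured step, a number no higher from compound 2 to compound 3 (the limit leaves the size open), changes a saturated chain carbon and leaves the carbonyl substituent untouched; the limit of > 10 ug/mL in this assay, at which 2 of the 3 values shown sit, shows how little the series resolves so far. Compound 4 `CCCC(=O)c1ccn(-c2ccc3c(c2)B(O)OC3)c1` differs from compound 2 as follows: propyl in place of 4-methylphenyl on a carbonyl carbon. For the measured compounds named here, no measured step touches the carbonyl carbon, so the change is untested. Compound 4 is expected to show a step that the limit leaves unreadable from compound 2 to compound 4, none beyond the scatter. Compound 4 is estimated at 15 ug/mL, between 7 ug/mL and 40 ug/mL.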

Compound 4, half-maximal inhibitory concentration: > 10 ug/mL
Compound 4 gave a limit, no number; the forecaster's own chance of this, stated with the estimate: 70%; the middle value lies beyond the limit too.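

Compound 2 and compound 4 both sit at a limit, so no step between them can be read: the limit of > 10 ug/mL in this assay, at which 3 of the 4 values shown sit.

As far as these compounds go, whether propyl in place of 4-methylphenyl on a carbonyl carbon shifts the read-out at all stays open.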